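The source may hold more compounds than are shown below. What is called first, only, known or untested is meant among the compounds shown, and "the series" means these compounds.

Measured so far:
- compound 1 `CC#CCn1c(N2CCC[C@@H](N)C2)nc2c1c(=O)n(CCCN1CCN(c3nc(-c4ccccc4)cs3)CC1)c(=O)n2C`: 650 nM
- compound 2 `CC#CCn1c(N2CCC[C@@H](N)C2)nc2c1c(=O)n(CCCN1CCN(c3noc(-c4ccccc4)n3)CC1)c(=O)n2C`: 1450 nM
- compound 3 `CC#CCn1c(N2CCC[C@@H](N)C2)nc2c1c(=O)n(CCCN1CCN(c3ncc(C(F)(F)F)cn3)CC1)c(=O)n2C`: 4020 nM

In a functional assay on HEK293 cells for agonist activity at Glucose-dependent insulinotropic receptor (Homo sapiens), read by a luciferase reporter (a lower number here means that less compound is needed, a higher number that more compound is needed for the effect), compound 1 gives 650 nM, the lowest number of the three. Compound 4 `CC#CCn1c(N2CCC[C@@H](N)C2)nc2c1c(=O)n(CCCN1CCN(c3ncc(CC)cn3)CC1)c(=O)n2C` differs from compound 1 by the change (5-ethylpyrimidin-2-yl in place of 4-phenyl-1,3-thiazol-2-yl on an amine nitrogen in a ring). The step that bears most directly on it is a 6.2-fold higher number from compound 1 to compound 3 (0.79 log units; beyond the scatter), where a different pyrimidin-2-yl entered at the same place; the step of a 2.2-fold higher number from compound 1 to compound 2 (0.35 log units; beyond the scatter) also went up. Both replacements of the 4-phenyl-1,3-thiazol-2-yl raised the number, so a higher number is expected for compound 4 as well. Going by the values given here, no measured compound carries an ethyl group, so the size is uncertain. Compound 4 is estimated at 2500 nM (range 1000 nM to 6500 nM), an expected step of a 3.8-fold higher number from compound 1 to compound 4 (0.59 log units; beyond the scatter).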

Compound 4, half-maximal effective concentration: 3990 nM
The estimate for compound 4 lay 1.6-fold (0.20 log units) below the measured number; measured number inside the range.
By their numbers in this assay, from the lowest: compound 1; then compound 2; then compounds 4 and 3 (each within the scatter of the next).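

On the pyrimidin-2-yl ring, ethyl and trifluoromethyl cannot be told apart here, with a 1.0-fold lower number from compound 3 to compound 4 (0.00 log units; within the scatter). Changing that one group therefore leaves the number unmoved, while the step from the phenyl-bearing groups remains large, with a 6.1-fold higher number from compound 1 to compound 4 (0.79 log units; beyond the scatter) and a 2.8-fold higher number from compound 2 to compound 4 (0.44 log units; beyond the scatter). No measurement available here explains this. From the compounds shown here alone, it remains open whether the lower numbers of compound 1 and compound 2 go with their phenyl ring or with their five-membered rings. A phenyl group on the pyrimidin-2-yl ring, or an amine or carboxylic acid in place of ethyl, would test how far this insensitivity extends.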